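Sulfonamide nitrogen methylation in the shared core series

The source may hold more compounds than are shown below. What is called first, only, known or untested is meant among the compounds shown, and "the series" means these compounds.

Two compounds of this series have a measurement in an assay on Sf9 cells for inhibition of serine/threonine-protein kinase 4 (Homo sapiens), read by luminescence and ADP-Glo, with a stated time of 1 h, in the presence of a further agent that is not named here; a lower number here means a stronger inhibitor, a higher number a weaker inhibitor. Compound 1 `CN1C(=O)C(c2c(F)cccc2F)N(C)c2nc(Nc3ccc(S(N)(=O)=O)cc3)ncc21` carries a sulfonamide with both nitrogen hydrogens in place; in this assay compound 1 gives 42 nM. Compound 2 `CNS(=O)(=O)c1ccc(Nc2ncc3c(n2)N(C)C(c2c(F)cccc2F)C(=O)N3C)cc1` differs from it by a methyl in place of hydrogen on the sulfonamide nitrogen, and in this assay compound 2 gives 318 nM. Among the two numbers, compound 2 stands highest, with compound 1 as its nearest neighbour; the step is a 7.6-fold higher number from compound 1 to compound 2 (0.88 log units; beyond the scatter).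

Compound 3 `CN1C(=O)C(c2c(F)cccc2F)N(C)c2nc(Nc3ccc(S(=O)(=O)N(C)C)cc3)ncc21` is not yet measured. It differs from compound 2 as follows: methyl in place of hydrogen on a sulfonamide nitrogen. Among the compounds with values here, the only measured step that bears on this is the one from compound 1 to compound 2, where the first methyl on the same nitrogen cost a 7.6-fold higher number from compound 1 to compound 2 (0.88 log units; beyond the scatter). A second methyl on that nitrogen is therefore expected to move the number further in the same direction, beyond the scatter, though with no certainty about its size. The expected step is a 3.8-fold higher number from compound 2 to compound 3 (0.58 log units; beyond the scatter). For compound 3 in this assay the estimate is 1200 nM, with a range from 400 nM to 4000 nM.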

Compound 3, half-maximal inhibitory concentration: 181 nM
Beside the measured number, compound 3's estimate is 6.6-fold (0.82 log units) above it, and the stated range ends above it.
By their numbers in this assay, from the lowest: compound 1; then compounds 3 and 2 (each within the scatter of the next).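

In this assay, a second methyl on the sulfonamide nitrogen gives a 1.8-fold lower number from compound 2 to compound 3 (0.24 log units; within the scatter), so the methylsulfamoyl and dimethylsulfamoyl groups are not separated here, and the penalty seen for the first methyl does not build with the second. Dimethylamino in place of amino on the sulfonyl sulfur gives a 4.3-fold higher number from compound 1 to compound 3 (0.63 log units; beyond the scatter), so both methylated compounds remain apart from compound 1, and across these three compounds the measured division lies between no methyl and any methyl on this nitrogen, not in the number of methyls. Nothing measured in the series accounts for this pattern, which therefore stands as an observation without an explanation.

Still open, on these data alone, is whether this level holds for larger groups on the same nitrogen, such as an ethyl group, a longer chain, or a chain ending in an amine or a carboxylic acid. Also open, as far as these compounds go, is whether the same pattern of one step beyond the scatter followed by one within it would appear with a different group in place of the 2,6-difluorophenyl ring on the shared core.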